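This account rests on a few compounds, and the source may have more. Where it says the series, first, only, none or still open, it means among the compounds named here.

Three compounds share one core and differ only in the group on the aromatic nitrogen: compound 1 `Oc1cc(C(F)(F)F)ccc1-c1nc(-c2ccccc2O)n(-c2ccc(Cl)cc2)n1` carries a 4-chlorophenyl group, compound 2 `Oc1cc(C(F)(F)F)ccc1-c1nc(-c2ccccc2O)n(-c2ccc(I)cc2)n1` a 4-iodophenyl group, and compound 3 `Oc1cc(C(F)(F)F)ccc1-c1nc(-c2ccccc2O)n(-c2ccc(F)cc2F)n1` a 2,4-difluorophenyl group. In a functional assay on PC-12 cells (Rattus norvegicus) for cytotoxicity, read by MTT assay, with stated times of 2 h and 24 h, tested at 10 uM (on this read-out higher numbers stand for a stronger effect at the one concentration tested and lower numbers for a weaker effect), compound 1 gives 96.1%. In this assay compound 2 gives 105%, and compound 3 gives 97.9%. Compound 2 holds the highest of the three numbers, but a number 8.9 percentage points higher from compound 1 to compound 2 (within the scatter) and a number 7.1 percentage points lower from compound 2 to compound 3 (within the scatter) both lie within the scatter, as does a number 1.8 percentage points higher from compound 1 to compound 3 (within the scatter), so no ordering can be read into the three.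

Compound 4 `Oc1cc(C(F)(F)F)ccc1-c1nc(-c2ccccc2O)n(-c2ccc(Cl)cc2Cl)n1` has not yet been measured. Relative to compound 2 the change is 2,4-dichlorophenyl in place of 4-iodophenyl on an aromatic nitrogen. The measured steps that bear on it are a number 8.9 percentage points higher from compound 1 to compound 2 (within the scatter), a number 7.1 percentage points lower from compound 2 to compound 3 (within the scatter) and a number 1.8 percentage points higher from compound 1 to compound 3 (within the scatter); each of them exchanges the group on the aromatic nitrogen or the halogen on it, and none leaves the scatter. On that basis the step of a number 5 percentage points lower from compound 2 to compound 4 (within the scatter) is expected to stay within the scatter, with no definite direction. Compound 4 is therefore estimated at 100% in this assay, with an expected range from 88% to 112%.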

Compound 4, a percentage reported as activity, at one concentration (the size of the read-out at that concentration, not a potency): 95.2%
Compound 4: the middle estimate sits 4.8 percentage points above what was measured; low and high end bracket the measured number.
By their numbers in this assay, from the lowest: compounds 4, 1, 3 and 2 (each within the scatter of the next).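

Among these compounds, compound 1 and compound 4 form the only pair here in which a halogen is added while the existing chloro stays: chloro in place of hydrogen on an aromatic carbon gives a number 0.9 percentage points lower from compound 1 to compound 4 (within the scatter) in this assay, so this added chlorine on the phenyl group at the aromatic nitrogen shifts the read-out by no more than repeat measurements would. The two disubstituted phenyl groups also cannot be told apart, with 2,4-dichlorophenyl in place of 2,4-difluorophenyl giving a number 2.7 percentage points lower from compound 3 to compound 4 (within the scatter), and the exchange of 4-iodophenyl for 2,4-dichlorophenyl, at a number 9.8 percentage points lower from compound 2 to compound 4 (within the scatter), likewise shows this position tolerating a change in both the number and the kind of halogens without a readable effect. Nothing at hand explains why these halogen changes leave the read-out within the scatter.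

All groups shown at this position are halogenated phenyl rings, so it remains open whether an amine or a carboxylic acid on that phenyl ring, or a longer alkyl chain in its place, would produce a step beyond the scatter. The trifluoromethyl group and the two hydroxyl groups of the shared core stay constant throughout, which leaves their contribution to the read-out unknown.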